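Cytotoxicity limits in the series and compound 4

A few compounds are considered here, and "the series" means these few. Any claim that something is new, unique, unknown or untested is made for them only; others in the source may bear on it.

Of the compounds shown here, three have been read in an ADME assay on TZM cells (Homo sapiens) for cytotoxicity, read by XTT assay, with a stated time of 4 days (on this read-out lower numbers stand for higher toxicity in this test and higher numbers for lower toxicity in this test), and none gives a number. Compound 1 `CNC(=O)c1cc2ncn(-c3ccc(C#N)cc3)c2cc1Oc1c(C)cc(/C=C/C#N)cc1C` gives > 890000 nM as a limit of the assay. Compound 3 `Cc1cc(/C=C/C#N)cc(C)c1Oc1cc(Nc2ccc(C#N)cc2)c(N)cc1[N+](=O)[O-]` gives > 24400 nM as a limit too. Compound 2 `CNC(=O)c1cc(N)c(Nc2ccc(C#N)cc2)cc1Oc1c(C)cc(CCC#N)cc1C` gives > 9100 nM and this is also only a limit, so it has no ranked place among the three values.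

Compound 4 `Cc1cc(CCC#N)cc(C)c1Oc1cc(Nc2ccc(C#N)cc2)c(N)cc1CO` carries hydroxymethyl in place of the methylcarbamoyl of compound 2 on an aromatic carbon, para to a (4-cyanophenyl)amino group and meta to an amino group. The counted change is hydroxymethyl in place of methylcarbamoyl on an aromatic carbon and nothing else differs. Among the measured compounds shown here, no measured pair isolates this swap.

The expected step that the limit leaves unreadable from compound 2 to compound 4 is estimated to stay within the usual scatter, with no firm direction. That expectation has a single anchor in compound 2 with its limit of > 9100 nM as the reference. Compound 4 is estimated at 12000 nM with an expected range of 3000 nM to 50000 nM in this assay. It too may well give only a limit of the assay.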

Compound 4, half-maximal cytotoxic concentration: > 23800 nM
Compound 4 ended at the assay's limit; the forecaster's own chance of this, stated with the estimate: 75%; middle value at least 1.9-fold (0.29 log units) from the limit.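

In this assay compound 4 gives > 23800 nM, which is a limit of the assay. Among the compounds shown here, compound 2 gives > 9100 nM, also a limit, so no step between compound 2 and compound 4 can be read. The compounds shown leave open whether hydroxymethyl in place of methylcarbamoyl changes this read-out at all.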